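Amide Substituent Swap and Oral Exposure in Mice

This account rests on a few compounds, and the source may have more. Where it says the series, first, only, none or still open, it means among the compounds named here.

Measured so far:
compound 1 `NCc1cc(Oc2cccc(C(=O)N3CC[C@@H](N)C3)c2)nc(C(F)(F)F)c1` gives 670 nM
compound 2 `CONC(=O)c1cccc(Oc2cc(CN)cc(C(F)(F)F)n2)c1` gives 630 nM

In an ADME assay on the whole organism (plasma, Mus musculus) for pharmacokinetics, read by LC-MS, at a dose of 30 mg/kg by the oral route (on this read-out higher numbers stand for higher exposure at the dose given and lower numbers for lower exposure), compound 2 sits alongside compound 1, since the step of a 1.1-fold lower number from compound 1 to compound 2 (0.03 log units; within the scatter) is within the scatter; neither number can be placed above the other. Compound 3 `NCc1cc(Oc2cccc(C(=O)NCCn3cnnn3)c2)nc(C(F)(F)F)c1` differs from compound 2 by 2-(1H-tetrazol-1-yl)ethyl in place of methoxy on an amide-type nitrogen. Within the data shown here, the only measured step, a 1.1-fold lower number from compound 1 to compound 2 (0.03 log units; within the scatter), also exchanged the group on the amide-type nitrogen and left exposure unchanged. No step beyond the scatter is therefore expected, and the estimated step is a 1.1-fold lower number from compound 2 to compound 3 (0.02 log units; within the scatter). Compound 3 is estimated at 600 nM, with a range from 200 nM to 1800 nM.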

Compound 3, maximal plasma concentration: 1990 nM
The estimate for compound 3 lay 3.3-fold (0.52 log units) below the measured number; measured number outside the range, above it.
By their numbers in this assay, from the lowest: compounds 2 and 1 (each within the scatter of the next); then compound 3.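

In this assay, the group on the amide-type nitrogen can change the number after all: 2-(1H-tetrazol-1-yl)ethyl in place of methoxy gives a clear step (a 3.2-fold higher number from compound 2 to compound 3 (0.50 log units; beyond the scatter)), whereas the earlier exchange stayed within the scatter. The same group also stands clear of 3-aminopyrrolidin-1-yl on the carbonyl carbon (a 3.0-fold higher number from compound 1 to compound 3 (0.47 log units; beyond the scatter)). Nothing available here explains these rises. From the compounds shown here alone, it remains open whether the tetrazole ring or the ethyl chain carries the step, and a 2-methoxyethyl or 2-(1H-imidazol-1-yl)ethyl group on that nitrogen would help separate the two.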